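The source may hold more compounds than are shown below. What is called first, only, known or untested is meant among the compounds shown, and "the series" means these compounds.

Measured in an ADME assay on microsomes from liver (Homo sapiens) for metabolic stability, read by LC-MS, using NADPH, with a stated time of 10 min, tested at 0.5 uM; a higher number here means that more of the compound is left, a lower number that less of the compound is left:

compound 1, `COC(=O)Nc1cc(-c2ccc(OC[C@@](C)(N)CC(C)C)c(C)c2)ccn1`: 98%
compound 2, `COC(=O)Nc1cc(-c2ccc(OC[C@@](C)(N)CC(C)C)cn2)ccn1`: 93%
compound 3, `COC(=O)Nc1cc(-c2cc(C)c(OC[C@@](C)(N)CC(C)C)cn2)ccn1`: 100%

The difference between the core of compound 1 and the core of compound 2 is not broken down here. Compound 3 is compound 2 with methyl in place of hydrogen on an aromatic carbon, and this step gave a number 7 percentage points higher from compound 2 to compound 3 (within the scatter).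

Compound 4, `COC(=O)Nc1cc(-c2ccc(OC[C@@](C)(N)CC(C)C)c(C)c2C)ccn1`, is not yet measured in this assay. It is compound 1 with methyl in place of hydrogen on an aromatic carbon. This is the same kind of change as from compound 2 to compound 3, but the place differs: in compound 3 the methyl enters on a six-membered aromatic ring with 1 nitrogen, ortho to the (2-amino-2,4-dimethylpentyl)oxy group, meta to a large group and opposite the ring nitrogen; in compound 4 it enters on a six-membered aromatic ring of carbon only, ortho to a large group, ortho to a methyl group and meta to the (2-amino-2,4-dimethylpentyl)oxy group.

The expected step in this assay is a number 1 percentage points lower from compound 1 to compound 4 (within the scatter), because compound 1 already gives 98% and because the earlier methyl step a number 7 percentage points higher from compound 2 to compound 3 (within the scatter) stayed within the scatter. Compound 4 is expected to give 97%, estimated between 88% and 100%.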

Compound 4, percent of the compound remaining: 93%
Compound 4: the middle estimate sits 4 percentage points above what was measured; the measured number falls inside the stated range.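

In this assay, methyl in place of hydrogen on an aromatic carbon gave a number 5 percentage points lower from compound 1 to compound 4 (within the scatter). The two methyl steps cannot be told apart: the same change on two cores in this assay, a number 7 percentage points higher (within the scatter) from compound 2 to compound 3 and a number 5 percentage points lower (within the scatter) from compound 1 to compound 4, 12 percentage points apart, within the scatter of two such steps. The change therefore carries to the core of compound 1 without a step beyond the scatter, but this does not show that the two cores respond alike, and as the methyl enters at a different place on each core, the effect of place cannot be separated from that of core.

Methyl is the only group shown entering on an aromatic carbon, leaving open how fluorine, chlorine or methoxy would read at these places. Also open, as far as these compounds go, is how the number would respond to a shorter chain in place of the (2-amino-2,4-dimethylpentyl)oxy group.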